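A few compounds are considered here, and "the series" means these few. Any claim that something is new, unique, unknown or untested is made for them only; others in the source may bear on it.

Compound 1 `CC#CCn1c(N2CCC[C@@H](N)C2)nc2c1c(=O)n(Cc1cc(OC)ccc1C(=O)O)c(=O)n2C` was run in an ADME assay on isolated protein for inhibition of Dipeptidyl peptidase 9 (Homo sapiens), with stated times of 15 min, 60 s and 20 min; a lower number here means a stronger inhibitor, a higher number a weaker inhibitor. In this assay compound 1 gives > 100000 nM, which is a limit of the assay rather than a number. Compound 2 `CC#CCn1c(N2CCC[C@@H](N)C2)nc2c1c(=O)n(Cc1c(Cl)cccc1C(=O)OC)c(=O)n2C` shares the same core with compound 1. In this assay compound 2 gives > 100000 nM, again a limit and not a measured number. The step that the two limits leave unreadable from compound 1 to compound 2 therefore cannot be read, since the two measured values share (the limit of > 100000 nM in this assay, at which 2 of the 2 values shown sit).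

Compound 3 `CC#CCn1c(N2CCC[C@@H](N)C2)nc2c1c(=O)n(Cc1ccc(F)cc1C(=O)O)c(=O)n2C` has not yet been measured. It differs from compound 1 by 2-carboxy-4-fluorophenyl in place of 2-carboxy-5-methoxyphenyl on a saturated chain carbon bound to an aromatic nitrogen. Among the compounds with values here, only one measured step exists among the compounds in hand, and it bears on this change merely by showing that swapping the whole group on that chain carbon for a quite different one left the result at the same limit; its size is not readable. No step beyond the usual scatter is therefore expected from this smaller change in this assay. The step expected in this assay is a number no higher from compound 1 to compound 3 (the limit leaves the size open). Compound 3 is estimated at 100000 nM, within a range from 30000 nM to 300000 nM, and the most likely outcome is once more a limit rather than a number.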

Compound 3, half-maximal inhibitory concentration: > 100000 nM
Compound 3 gave a limit, no number (the forecaster's own chance of this, stated with the estimate: 85%); the middle value lies on the limit itself.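

The steps linking compound 3 with compound 1 and compound 2 cannot be read, because all three compounds share one limit of the assay rather than numbers: the limit of > 100000 nM in this assay, at which 3 of the 3 values shown sit.

The compounds shown leave open how strongly any of them inhibits the enzyme in this assay, and whether changing the group on the saturated chain carbon bound to an aromatic nitrogen alters that inhibition at all.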